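Carbamoyl to Methoxycarbonyl: How Much Compound Do Cells Tolerate?

The compounds below may be only part of what the source reports. "The series", "measured", "known", "first", "only" and "open" are said of these compounds alone.

Compound 1 `Cc1cc(/C=C/C#N)cc(C)c1Oc1cc(Nc2ccc(C#N)cc2)c(N)cc1C(N)=O` is followed here in an ADME assay on TZM cells (Homo sapiens) for cytotoxicity, read by XTT assay, with a stated time of 4 days (a higher number here means that more compound is tolerated, a lower number that less compound is tolerated), and gives > 23600 nM as a limit of the assay, not a number. Compound 2 `Cc1cc(CCC#N)cc(C)c1Oc1cc(Nc2ccc(C#N)cc2)c(N)cc1N` carries different groups on the shared core. In this assay compound 2 gives > 25000 nM as a limit too. Neither compound therefore has an exact half-maximal cytotoxic concentration.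

Compound 3 `COC(=O)c1cc(N)c(Nc2ccc(C#N)cc2)cc1Oc1c(C)cc(/C=C/C#N)cc1C` keeps the core of compound 1 and changes one group (methoxy in place of amino on a carbonyl carbon). In words, methoxy stands in place of amino on a carbonyl carbon, turning carbamoyl into methoxycarbonyl. Within the data shown here, no pair of measured compounds shows what this change does in this assay so only a cautious expectation is possible. The one anchor for it is compound 1 with its limit of > 23600 nM as the starting point. The expected change is an at least 1.1-fold lower number from compound 1 to compound 3 (0.07 log units; that floor lies within the scatter) as a small move toward less compound tolerated, possibly no larger than the usual scatter. The assay may well report only a limit again. For compound 3 the estimated value is 20000 nM with an expected range from 7000 nM to 40000 nM around it.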

Compound 3, half-maximal cytotoxic concentration: > 22800 nM
Compound 3: a limit, no number (the forecaster's own chance of this, stated with the estimate: 60%); middle value at least 1.1-fold (0.05 log units) from the limit.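

In this assay, among these compounds, compound 1 and compound 3 both give only limits, not numbers, so no step between them can be read. The compounds shown leave open the exact half-maximal cytotoxic concentration of each, and so whether methoxy in place of amino on a carbonyl carbon changes how much compound is tolerated.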